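The source may hold more compounds than are shown below. What is called first, only, known or untested is meant among the compounds shown, and "the series" means these compounds.

Working notes on the series.

Compound 3 `Cc1c(Cl)cccc1-c1cccc(COc2ccc([C@H](CC(=O)O)c3nccn3C)cc2)c1` is the compound whose step is followed here. In an assay on CHO cells for agonist activity at Free fatty acid receptor 1 (Homo sapiens), read by luminescence, with a stated time of 20 s, in the presence of a further agent that is not named here (on this read-out higher numbers stand for an effect only at larger amounts of compound and lower numbers for an effect already at smaller amounts), compound 3 gives 61 nM, the second highest of the three numbers measured; its nearest neighbour is compound 1 `Cc1ccccc1-c1cccc(COc2ccc([C@H](CC(=O)O)c3nccn3C)cc2)c1`, which in this assay gives 43 nM, and the furthest is compound 2 `Cc1cc(Cl)ccc1-c1cccc(COc2ccc([C@H](CC(=O)O)c3nccn3C)cc2)c1C`, which gives 240 nM. For the measured compounds named here, the only single-point step measured so far is a 1.4-fold higher number from compound 1 to compound 3 (0.15 log units; within the scatter), compound 3 carrying a chloro where compound 1 carries none; compound 2 differs from compound 3 in more than one place, so its number only shows that it sits beyond the scatter from compound 3.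

The step to compound 4 `Cn1ccnc1[C@@H](CC(=O)O)c1ccc(OCc2cccc(-c3ccccc3Cl)c2)cc1` is 2-chlorophenyl in place of 3-chloro-2-methylphenyl on an aromatic carbon. Going by the values given here, no measured step matches it; the one step that bears on it, from compound 1 to compound 3, stayed within the scatter, and the rings leaving and entering carry no donors or acceptors. No step beyond the scatter is therefore expected in this assay, the estimated step being a 1.1-fold lower number from compound 3 to compound 4 (0.04 log units; within the scatter). For compound 4 the expected value is 55 nM, with a range from 20 nM to 150 nM.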

Compound 4, half-maximal effective concentration: 43 nM
Compound 4: the middle estimate sits 1.3-fold (0.11 log units) above what was measured; low and high end bracket the measured number.
By their numbers in this assay, from the lowest: compounds 1, 4 and 3 (each within the scatter of the next); then compound 2.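

In this assay, the swap of 3-chloro-2-methylphenyl for 2-chlorophenyl gives a 1.4-fold lower number from compound 3 to compound 4 (0.15 log units; within the scatter), and chloro in place of methyl gives no change at the digits printed from compound 1 to compound 4 (within the scatter). The earlier step showed only that a chloro could be added with the methyl kept; these two show that the methyl can be replaced by chloro, and that a ring carrying a methyl and a chloro can give way to one carrying a chloro alone, without a step beyond the scatter. Across compound 1, compound 3 and compound 4, this ring therefore tolerates these small changes, a reading that does not extend to compound 2, which differs in more than one place.

From the compounds shown here alone, whether a methoxy, a nitrile, a trifluoromethyl or an amine on this ring would also stay within the scatter remains open. So does whether a ring other than phenyl would be tolerated here.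

Nothing available accounts for these numbers.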